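A few compounds are considered here, and "the series" means these few. Any claim that something is new, unique, unknown or untested is made for them only; others in the source may bear on it.

Within the data shown here, the three measured members share one core, differing only in the group attached through the oxygen on an unsaturated carbon, and all three have been tested in an ADME assay on HEL cells (Homo sapiens) for cytotoxicity, with a stated time of 3 days; on this read-out lower numbers stand for higher toxicity in this test and higher numbers for lower toxicity in this test. Compound 1 `CCC1(Cc2ccccc2)OS(=O)(=O)C=C1OCc1ccccc1` gives 200000 nM in this assay. Compound 2 `CCC1(Cc2ccccc2)OS(=O)(=O)C=C1OC(=O)c1ccccc1` returns only a limit of the assay, > 200000 nM. This value is the one of three that sits at the limit of > 200000 nM in this assay, at which 1 of the 3 values shown sits. Compound 3 `CCC1(Cc2ccccc2)OS(=O)(=O)C=C1OCCCc1ccccc1` gives 133000 nM in this assay, and against compound 1 this is a 1.5-fold lower number from compound 1 to compound 3 (0.18 log units; within the scatter), so the two plain numbers lie close together. The move from compound 1 to compound 2 is a number no lower from compound 1 to compound 2 (the limit leaves the size open).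

Compound 4 `CCC1(Cc2ccccc2)OS(=O)(=O)C=C1OCC=C(C)C` has not been measured. It differs from compound 3 in one place: 2-methylprop-1-en-1-yl in place of phenethyl on a saturated chain carbon bound to an oxygen on an unsaturated carbon. Among the measured compounds shown here, the one measured step at this position, which was a 1.5-fold lower number from compound 1 to compound 3 (0.18 log units; within the scatter), stayed within the scatter, and the step to compound 2 returned only a limit, so nothing measured here shows that exchanging the group on the saturated chain carbon bound to an oxygen on an unsaturated carbon moves the number beyond the scatter. Because that earlier change gave a 1.5-fold lower number from compound 1 to compound 3 (0.18 log units; within the scatter), compound 4 is expected to show a 1.3-fold higher number from compound 3 to compound 4 (0.11 log units; within the scatter). Compound 4 is estimated at 170000 nM, with a range from 60000 nM to 250000 nM.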

Compound 4, half-maximal cytotoxic concentration: 112000 nM
Beside the measured number, compound 4's estimate is 1.5-fold (0.18 log units) above it; measured number inside the range.
By their numbers in this assay, from the lowest: compounds 4, 3 and 1 (each within the scatter of the next).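

In this assay, 2-methylprop-1-en-1-yl in place of phenethyl on a saturated chain carbon bound to an oxygen on an unsaturated carbon gives a 1.2-fold lower number from compound 3 to compound 4 (0.07 log units; within the scatter), and the corresponding exchange for phenyl gives a 1.8-fold lower number from compound 1 to compound 4 (0.25 log units; within the scatter). The earlier compounds shown here all carried a six-membered aromatic ring of carbon only in this group, whereas the entering group has no ring, 4 heavy atoms rather than the 8 of phenethyl, and 1 double bond outside aromatic rings, yet neither step leaves the scatter. The comparison with the benzoyl group reads an at least 1.7-fold lower number from compound 2 to compound 4 (0.25 log units; that floor lies within the scatter) and rests on a limit of the assay: the limit of > 200000 nM in this assay, at which 1 of the 4 values shown sits.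

The compounds shown leave open whether any group at this place can move the number beyond the scatter, since all of them carry only carbon-based ether groups or the benzoyl group there, and an amine, a carboxylic acid or a much longer chain does not appear among them. They also leave open how the number responds to changes elsewhere, since the rest of the shared core stays the same throughout.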